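Aryl ether swap in a two-compound antiproliferative series

A few compounds are considered here, and "the series" means these few. Any claim that something is new, unique, unknown or untested is made for them only; others in the source may bear on it.

Of the compounds shown here, two have numbers so far. Compound 1 `Cc1nn(C)c(Oc2ccc(F)cc2)c1/C=N\CCCCCOc1cc2oc(=O)cc(C)c2cc1Cl` gives 22100 nM in a functional assay on SMMC-7721 cells (Homo sapiens) for antiproliferative activity, read by MTT assay, with a stated time of 72 h; on this read-out higher numbers stand for weaker inhibition and lower numbers for stronger inhibition. Compound 2 `Cc1nn(C)c(Oc2cccc(F)c2F)c1/C=N\CCCCCCOc1cc2oc(=O)cc(C)c2cc1Cl` gives 22800 nM in this assay. Compound 2 carries the higher of the two numbers, but the gap to compound 1 lies within the scatter, so the two cannot be ordered against each other. Within the data shown here, compounds 1 and 2 differ in more than one place, and no single step between them is available.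

Compound 3 `Cc1nn(C)c(Oc2ccccc2Br)c1/C=N\CCCCCCOc1cc2oc(=O)cc(C)c2cc1Cl` is the next candidate. Its change from compound 2 is 2-bromophenyl in place of 2,3-difluorophenyl on an oxygen on an aromatic ring: the 2,3-difluorophenoxy group becomes a 2-bromophenoxy group, with one heavy atom fewer and no change in donors, acceptors or charge.

Nothing measured shows how a change at this aryl ether moves the read-out. With both measured compounds sitting at one level, the expected step from compound 2 to compound 3 is a 1.0-fold lower number from compound 2 to compound 3 (0.02 log units; within the scatter), that is, none beyond the scatter. On this basis compound 3 is estimated at 22000 nM in this assay, with a range from 9000 nM to 55000 nM.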

Compound 3, half-maximal inhibitory concentration: 19700 nM
Estimate against measurement, compound 3: 1.1-fold (0.05 log units) above, within the range that was stated.
By their numbers in this assay, from the lowest: compounds 3, 1 and 2 (each within the scatter of the next).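

Among these compounds, with the rest of compound 2 held constant, placing 2-bromophenyl in place of 2,3-difluorophenyl on an oxygen on an aromatic ring gives a 1.2-fold lower number from compound 2 to compound 3 (0.06 log units; within the scatter) in this assay, the first direct reading at this aryl ether position. The exchange replaces two fluorine atoms on the ring with one bromine atom and leaves the donor, acceptor and charge counts unchanged, yet the read-out does not separate the two compounds, so this particular change has no effect that can be distinguished from the scatter. No measured property of the compounds is available to bear on this result.

On these data alone, whether this position responds to a group of another kind, such as an amine or a carboxylic acid on the phenyl ring, or to a plain phenyl group, remains open, as a single step between two halogen-bearing rings cannot show how far the flat read-out extends. Among the compounds shown here, the linking chain also remains open, since compound 1 differs from compound 2 in more than one place and no step isolates the effect of a shorter or longer chain.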